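The source may hold more compounds than are shown below. What is called first, only, known or untested is meant among the compounds shown, and "the series" means these compounds.

Of the compounds shown here, three have so far been measured in a functional assay on EKVX cells (Homo sapiens) for inhibition, read by sulforhodamine B assay, with a stated time of 48 h; on this read-out higher numbers stand for weaker inhibition of growth and lower numbers for stronger inhibition of growth. Compound 1 `O=C(Nc1ccccc1OC(F)(F)F)Nc1n[nH]c2ccccc12` gives 48200 nM. Compound 2 `Nc1nn(C(=O)Nc2ccc(Cc3ccccc3)cc2)c2ccccc12` gives 11200 nM, the lower of the two numbers, and the gap between compound 1 and compound 2 lies beyond the usual scatter of repeated measurements. Compound 3 `COc1ccc(NC(=O)Nc2n[nH]c3ccccc23)cc1` reaches only a limit of the assay, > 100000 nM; this is the limit of > 100000 nM in this assay, at which 1 of the 3 values shown sits.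

Compound 4 `CCCCOc1ccc(NC(=O)n2nc(N)c3ccccc32)cc1` has not yet been measured. It differs from compound 2 in one place: butoxy in place of benzyl on an aromatic carbon. Going by the values given here, no pair of measured compounds traces this change on its own, since compound 1 and compound 3 differ from compound 2 both in the outer group and in the way the urea is joined to the shared core. What the numbers show is that the two compounds carrying an oxygen-linked group on the outer ring, compound 1 and compound 3, sit at the weaker end, while compound 2 with its benzyl group gives the lowest number. On that basis the step is expected to run toward weaker inhibition, roughly a 2.5-fold higher number from compound 2 to compound 4 (0.40 log units; beyond the scatter). Compound 4 is therefore estimated at 28000 nM, with a likely range from 9000 nM to 90000 nM.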

Compound 4, concentration for 50% growth inhibition: 13300 nM
Beside the measured number, compound 4's estimate is 2.1-fold (0.32 log units) above it, within the range that was stated.
By their numbers in this assay, from the lowest: compounds 2 and 4 (each within the scatter of the next); then compound 1. At a limit, above all of these: compound 3.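

In this assay, the change at this position makes little difference to the number: a 1.2-fold higher number from compound 2 to compound 4 (0.07 log units; within the scatter). At this place, para to a large group, benzyl carries a six-membered aromatic ring while butoxy has no ring and brings in an oxygen atom, yet the two compounds cannot be told apart, so in this one pair the ring is not needed to keep the growth inhibition seen with compound 2. Nothing measured here explains why these two different groups read alike.

From the compounds shown here alone, it remains open whether the same would hold for other groups at this place, such as a small methyl, an amine, a carboxylic acid or a chain longer than butoxy. The compounds shown also include no pair that differs only in how the urea is joined to the shared core, so the effect of that join cannot be read on its own.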